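Ring size at the benzylic branch of a xanthine pair

A few compounds are considered here, and "the series" means these few. Any claim that something is new, unique, unknown or untested is made for them only; others in the source may bear on it.

Measured compounds:
compound 1 `CCCn1c(=O)c2nc(C(C3CC3)C3CC3)[nH]c2n(CCC)c1=O` — 3 nM in an assay on cell membranes for binding affinity to adenosine receptor A1 (Cavia porcellus); a lower number here means a stronger inhibitor, a higher number a weaker inhibitor
compound 2 `CCCn1c(=O)c2nc(C(c3ccccc3)C3CC3)[nH]c2n(CCC)c1=O` — 150 nM in this assay

For the measured compounds named here, compound 2 holds the higher of the two numbers; the only measured step, a 50-fold higher number from compound 1 to compound 2 (1.70 log units; beyond the scatter), concerns a different change at a different place. Compound 3 `CCCn1c(=O)c2nc(C(c3ccccc3)C3CCCC3)[nH]c2n(CCC)c1=O` carries cyclopentyl in place of cyclopropyl on a saturated chain carbon bound to two aromatic carbons. Going by the values given here, no measured step bears directly on this change, so the account rests on the neighbouring values alone. Compound 3 is expected to sit close to compound 2, with a modest shift upward as the estimated step of a 1.3-fold higher number from compound 2 to compound 3 (0.12 log units; within the scatter). The estimate for compound 3 is 200 nM, expected within 50 nM to 800 nM.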

Compound 3, inhibition constant: 400 nM
For compound 3 the middle estimate is 2.0-fold (0.30 log units) below the measured one, within the range that was stated.
By their numbers in this assay, from the lowest: compound 1; then compound 2; then compound 3.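

On a saturated chain carbon bound to two aromatic carbons, cyclopentyl in place of cyclopropyl gives a 2.7-fold higher number from compound 2 to compound 3 (0.43 log units; beyond the scatter) in this assay. With phenyl held in place, the size of the saturated ring at this carbon therefore still registers, and here the larger ring goes with the weaker binder. No available evidence bears on why this shift occurs. The two rings alone leave open how cyclobutyl or cyclohexyl would read at this carbon. They also leave open whether cyclopentyl would give a similar step without the phenyl.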